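Bromo for Methoxy on the Aryl Ketone Arm

The source may report more compounds than this note shows. Statements on the series, on what has been measured and on what is new or still open speak of the compounds shown alone.

Within the data shown here, compound 2 `COc1ccc(C(=O)CSc2nnc(-c3cc(OC)c(OC)c(OC)c3)n2N2C(=O)c3ccccc3C2=O)cc1` gives 37200 nM in a functional assay on MKN-45 cells (Homo sapiens) for cytotoxicity, read by MTT assay, with a stated time of 48 h (a lower number here means a stronger inhibitor, a higher number a weaker inhibitor), the only number among the values shown. Compound 1 `C#CCSc1nnc(-c2cc(OC)c(OC)c(OC)c2)n1N1C(=O)c2ccccc2C1=O` shows only a limit, > 200000 nM, in this assay. Among the measured compounds shown here, the single measured step, an at least 5.3-fold lower number from compound 1 to compound 2 (0.73 log units; beyond the scatter), concerns a different part of the molecule. Compound 3 `COc1cc(-c2nnc(SCC(=O)c3ccc(Br)cc3)n2N2C(=O)c3ccccc3C2=O)cc(OC)c1OC` differs from compound 2 by bromo in place of methoxy on an aromatic carbon. For the measured compounds named here, no measured step bears on this change; a shift beyond the scatter is not expected. Compound 3 is therefore estimated at 30000 nM in this assay, between 10000 nM and 100000 nM. The expected step is a 1.2-fold lower number from compound 2 to compound 3 (0.09 log units; within the scatter).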

Compound 3, half-maximal inhibitory concentration: 22300 nM
For compound 3 the middle estimate is 1.3-fold (0.13 log units) above the measured one; the measured number falls inside the stated range.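

Bromo and methoxy on this aromatic carbon, para to a large group, cannot be told apart in this assay: a 1.7-fold lower number from compound 2 to compound 3 (0.22 log units; within the scatter). With bromo as with methoxy, the aryl ketone arm keeps its clear gain over the ethynyl end of the chain: an at least 8.9-fold lower number from compound 1 to compound 3 (0.95 log units; beyond the scatter). Compound 1 gives only a limit, so this step is a bound and not a measured size: the limit of > 200000 nM in this assay, at which 1 of the 3 values shown sits.

On these data alone, whether an amine or a carboxylic acid on this aromatic carbon would move the number beyond the scatter stays open. So does whether any change here would bring the value of the series much lower.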